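The source may report more compounds than this note shows. Statements on the series, on what has been measured and on what is new or still open speak of the compounds shown alone.

In a physicochemical assay for solubility, in phosphate buffer, at pH 7.4 (a higher number here means a more soluble compound, a lower number a less soluble compound), compound 3 `Nc1nc(-c2ccc(OCc3ccccc3)cc2)cc(=O)[nH]1` gives < 1000 nM. That reading is a limit of the assay and not a number. Compound 1 `CC(C)(C)COc1ccc(-c2cc(=O)[nH]c(N)n2)cc1` gives 3100 nM, and compound 2 `Nc1nc(-c2ccc(OCC3CCOC3)cc2)cc(=O)[nH]1` gives 58000 nM. Compound 3 therefore stands lowest of the three.

Compound 4 `Nc1nc(-c2ccc(OCCCCO)cc2)cc(=O)[nH]1` is still unmeasured, and its difference is 3-hydroxypropyl in place of phenyl on a saturated chain carbon bound to an oxygen on an aromatic ring. Here, 3-hydroxypropyl takes the place of phenyl on a saturated chain carbon bound to an oxygen on an aromatic ring.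

All three measured steps change this same place. The first is a 19-fold higher number from compound 1 to compound 2 (1.27 log units; beyond the scatter). The second is an at least 3.1-fold lower number from compound 1 to compound 3 (0.49 log units; beyond the scatter). The closest guide is the third, in which oxolan-3-yl, also a group containing oxygen, gives way to phenyl: an at least 58-fold lower number from compound 2 to compound 3 (1.76 log units; beyond the scatter). Read in reverse, that large step points to a higher number on leaving phenyl.

A large upward step is therefore expected, estimated as an at least 40-fold higher number from compound 3 to compound 4 (1.60 log units; beyond the scatter). For compound 4, the estimated value in this assay is 40000 nM, with an expected range from 10000 nM to 150000 nM.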

Compound 4, solubility: 95000 nM
Beside the measured number, compound 4's estimate is 2.4-fold (0.38 log units) below it; the range from low to high includes it.
By their numbers in this assay, from the lowest: compound 1; then compounds 2 and 4 (each within the scatter of the next). At a limit, below all of these: compound 3.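

In this assay, 3-hydroxypropyl in place of phenyl on a saturated chain carbon bound to an oxygen on an aromatic ring gives an at least 95-fold higher number from compound 3 to compound 4 (1.97 log units; beyond the scatter). Going by these compounds alone, that size is only a lower bound, since compound 3 reads as a limit of the assay and not as a number: the limit of < 1000 nM in this assay, at which 1 of the 4 values shown sits. What the earlier compounds did not show is that an open chain ending in a hydroxyl group can match the ring of oxolan-3-yl, with a 1.6-fold higher number from compound 2 to compound 4 (0.21 log units; within the scatter), and that it also stands well clear of tert-butyl, with a 31-fold higher number from compound 1 to compound 4 (1.49 log units; beyond the scatter).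

On these data alone, what a plain propyl chain, or an amine or a carboxylic acid at the chain end, would give remains open. The part played by the hydroxyl group therefore cannot yet be told apart from the loss of the phenyl ring.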